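This account rests on a few compounds, and the source may have more. Where it says the series, first, only, none or still open, it means among the compounds named here.

Measured compounds in a functional assay on J774.A1 cells (Mus musculus) for inhibition, read by immunoassay, with a stated time of 12 h, tested at 30 uM; a higher number here means more inhibition at the concentration tested (going by the name of the read-out), a lower number less inhibition:
- compound 1 `CC(C)COc1ccccc1C1CC(=O)c2ccccc2O1`: 33.5%
- compound 2 `C=CCOc1ccccc1C1CC(=O)c2ccccc2O1`: 47%
- compound 3 `O=C1CC(c2ccccc2OCc2ccccc2)Oc2ccccc21`: 91.5%

Compound 2 sits second highest of the three numbers in this assay. Its nearest neighbour is compound 1, the step being a number 13.5 percentage points higher from compound 1 to compound 2 (beyond the scatter); its furthest is compound 3, with a number 44.5 percentage points higher from compound 2 to compound 3 (beyond the scatter). Both steps are beyond the scatter.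

Compound 4 `O=C1CC(c2ccccc2OCc2cccc(F)c2)Oc2ccccc21` is not yet measured. It differs from compound 2 by 3-fluorophenyl in place of vinyl on a saturated chain carbon bound to an oxygen on an aromatic ring.

Within the data shown here, the step most directly bearing on this change is the one from compound 2 to compound 3, where phenyl replaced vinyl on a saturated chain carbon bound to an oxygen on an aromatic ring and gave a number 44.5 percentage points higher from compound 2 to compound 3 (beyond the scatter). The same replacement of isopropyl by phenyl, from compound 1 to compound 3, gave a number 58 percentage points higher from compound 1 to compound 3 (beyond the scatter). Among the measured compounds shown here, no measured compound carries a fluorine, so the effect of the fluorine on the entering ring cannot be read from these three compounds; the expectation rests on the phenyl ring alone.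

Compound 4 is therefore expected to show a large upward step, a number 40 percentage points higher from compound 2 to compound 4 (beyond the scatter), in this assay. The estimate for compound 4 is 87%, with a range of 68% to 98%, the lower end leaving room for the untested fluorine.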

Compound 4, a percentage reported as inhibition, at one concentration (the size of the read-out at that concentration, not a potency): 92.7%
Estimate against measurement, compound 4: 5.7 percentage points below; the measured number falls inside the stated range.
By their numbers in this assay, from the lowest: compound 1; then compound 2; then compounds 3 and 4 (each within the scatter of the next).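

In this assay, among these compounds, the ring that enters at this place carries a fluorine for the first time, and fluoro in place of hydrogen on an aromatic carbon gives a number 1.2 percentage points higher from compound 3 to compound 4 (within the scatter), so compound 3 and compound 4 cannot be told apart here. The large gains over the non-aromatic groups stay in place with the substituted ring, with a number 45.7 percentage points higher from compound 2 to compound 4 (beyond the scatter) against vinyl and a number 59.2 percentage points higher from compound 1 to compound 4 (beyond the scatter) against isopropyl, which extends what plain phenyl showed to 3-fluorophenyl on a saturated chain carbon bound to an oxygen on an aromatic ring. No supporting evidence is available to explain these steps.

A read-out at one concentration leaves open how the potencies of compound 3 and compound 4 compare, since both give numbers that lie within the scatter of each other. Also open, on these data alone, is whether the number would hold with a carboxylic acid or an amine on the entering ring, or with a longer chain such as 2-phenylethyl in place of 3-fluorobenzyl.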